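The source may hold more compounds than are shown below. What is called first, only, known or untested is meant among the compounds shown, and "the series" means these compounds.

Measured in a functional assay on HT-29 cells (Homo sapiens) for antiproliferative activity, read by MTT assay, with a stated time of 48 h; a higher number here means a weaker inhibitor, a lower number a stronger inhibitor:

Compound 1, `N#Cc1ncn(-c2ccc(F)cc2)c1/N=C/c1ccc([N+](=O)[O-])cc1`: 15900 nM
Compound 2, `COc1ccc(/C=N/c2c(C#N)ncn2-c2ccc(F)cc2)cc1`: 19400 nM
Compound 3, `N#Cc1ncn(Cc2ccc(F)cc2)c1/N=C/c1ccc([N+](=O)[O-])cc1`: 5720 nM

Two single changes connect these compounds. The first, (methoxy in place of nitro on an aromatic carbon), gave a 1.2-fold higher number from compound 1 to compound 2 (0.09 log units; within the scatter). The second, (4-fluorobenzyl in place of 4-fluorophenyl on an aromatic nitrogen), gave a 2.8-fold lower number from compound 1 to compound 3 (0.44 log units; beyond the scatter), and compound 3 holds the lowest number of the three in this assay.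

Compound 4, `COc1ccc(/C=N/c2c(C#N)ncn2Cc2ccc(F)cc2)cc1`, has not yet been measured. It differs from compound 3 by methoxy in place of nitro on an aromatic carbon, the same change already seen between compound 1 and compound 2; the two cores on which it is made differ by 4-fluorobenzyl in place of 4-fluorophenyl on an aromatic nitrogen. Because that earlier step was a 1.2-fold higher number from compound 1 to compound 2 (0.09 log units; within the scatter), the step from compound 3 to compound 4 is expected to be small as well, about a 1.2-fold higher number from compound 3 to compound 4 (0.09 log units; within the scatter). On that basis compound 4 is estimated at 7000 nM in this assay, with a likely range from 3000 nM to 16000 nM.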

Compound 4, half-maximal inhibitory concentration: 9190 nM
For compound 4 the middle estimate is 1.3-fold (0.12 log units) below the measured one, and the stated range covers the measured number.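

In this assay, methoxy in place of nitro gave a 1.6-fold higher number from compound 3 to compound 4 (0.21 log units; within the scatter), and this change carried over between the two cores with no difference that can be told apart: the same change on two cores in this assay, a 1.2-fold higher number (0.09 log units; within the scatter) from compound 1 to compound 2 and a 1.6-fold higher number (0.21 log units; within the scatter) from compound 3 to compound 4, 1.3-fold (0.12 log units) apart, within the scatter of two such steps. Likewise, 4-fluorobenzyl in place of 4-fluorophenyl gave a 2.1-fold lower number from compound 2 to compound 4 (0.32 log units; beyond the scatter), and this change also carried over: the same change on two cores in this assay, a 2.8-fold lower number (0.44 log units; beyond the scatter) from compound 1 to compound 3 and a 2.1-fold lower number (0.32 log units; beyond the scatter) from compound 2 to compound 4, 1.3-fold (0.12 log units) apart, within the scatter of two such steps. This shows that the two changes combined consistently across these four compounds in this one assay, but it does not show that they would do so on other cores, and it gives no reason for either step.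

The compounds shown leave open how an amine or a carboxylic acid in place of nitro would behave on the six-membered aromatic ring. They also leave open what a longer chain in place of 4-fluorobenzyl on the aromatic nitrogen would do.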